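A few compounds are considered here, and "the series" means these few. Any claim that something is new, unique, unknown or untested is made for them only; others in the source may bear on it.

In a functional assay on HeLa cells (Homo sapiens) for antiproliferative activity, read by MTT assay, with a stated time of 48 h (on this read-out higher numbers stand for weaker inhibition and lower numbers for stronger inhibition), compound 1 `Oc1ccc2ccccc2c1C(Nc1nc2ccccc2s1)c1cn(-c2ccccc2)nc1-c1ccccc1` gives 17300 nM and compound 2 `COc1ccc2nc(NC(c3cn(-c4ccccc4)nc3-c3ccccc3)c3c(O)ccc4ccccc34)sc2c1` gives 8290 nM as its result. Compound 3 `COc1cccc(-c2nn(-c3ccccc3)cc2C(Nc2nc3ccc(Cl)cc3s2)c2c(O)ccc3ccccc23)c1` reads 30000 nM on the same scale. That number lies within the scatter of the value for compound 1, and beyond the scatter above the value for compound 2.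

Within the data shown here, compound 4 `Oc1ccc2ccccc2c1C(Nc1nc2ccc(Cl)cc2s1)c1cn(-c2ccccc2)nc1-c1ccccc1` has no measurement yet. It differs from compound 3 in one place, hydrogen in place of methoxy on an aromatic carbon on a six-membered aromatic ring of carbon only: hydrogen in place of methoxy on an aromatic carbon, which turns 3-methoxyphenyl into phenyl.

Among the measured compounds shown here, only one measured step offers any guidance. The step of a 2.1-fold lower number from compound 1 to compound 2 (0.32 log units; beyond the scatter) is modest and comes with methoxy in place of hydrogen on an aromatic carbon. Read backwards, it hints that losing a methoxy could raise the number slightly. However, that methoxy sits in a different part of the molecule, and a single pair shows no general rule.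

In this assay the expected change is therefore small, with no clear direction and nothing beyond the scatter, and the estimated step of a 1.1-fold lower number from compound 3 to compound 4 (0.05 log units; within the scatter) reflects this. The estimate for compound 4 is 27000 nM with 11000 nM to 60000 nM as the expected range.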

Compound 4, half-maximal inhibitory concentration: 12500 nM
Compound 4: the middle estimate sits 2.2-fold (0.33 log units) above what was measured, and the stated range covers the measured number.
By their numbers in this assay, from the lowest: compounds 2, 4, 1 and 3 (each within the scatter of the next, the first and the last beyond it).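

In this assay, replacing the methoxy of the 3-methoxyphenyl group with hydrogen gives a 2.4-fold lower number from compound 3 to compound 4 (0.38 log units; beyond the scatter), so at this position methoxy goes with the higher number, whereas on the core of compound 1 it went with the lower one. One methoxy-for-hydrogen change thus moves the number in opposite directions at two places in these molecules, and the earlier pair alone could not be carried over to this position: the same change on two cores in this assay, a 2.1-fold lower number (0.32 log units; beyond the scatter) from compound 1 to compound 2 and a 2.4-fold higher number (0.38 log units; beyond the scatter) from compound 4 to compound 3, 5.0-fold (0.70 log units) apart, beyond the scatter of two such steps. The chloro compound adds no such separation elsewhere in the molecule, since a 1.4-fold lower number from compound 1 to compound 4 (0.14 log units; within the scatter) and a 1.5-fold higher number from compound 2 to compound 4 (0.18 log units; within the scatter) both stay within the usual scatter of repeated measurements.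

At this position the compounds shown carry only methoxy and hydrogen, so it remains open how a hydroxy, a fluoro or an amine there would read in this assay. Among these compounds, with only two pairs, it also remains open whether the contrast between the two places would hold on other cores, or whether a methoxy elsewhere on the same ring would read like this one.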